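One more methyl on the methylamino nitrogen

A few compounds are considered here, and "the series" means these few. Any claim that something is new, unique, unknown or untested is made for them only; others in the source may bear on it.

In a functional assay on HCT-116 cells (Homo sapiens) for antiproliferative activity, read by MTT assay, with a stated time of 48 h (a lower number here means a stronger inhibitor, a higher number a weaker inhibitor), compound 3 `CCCCCCCCCC(CCO)n1cnc2c(NC)ncnc21` gives 5410 nM and stands in the middle of three measured numbers, above compound 2 `CCCCCCCCCC(CCO)n1cnc2c(OC)ncnc21` at 2530 nM, with compound 1 `CCCCCCCCC(CCO)n1cnc2c(N(C)C)ncnc21` still higher at 19800 nM on the same scale. The change methyl in place of hydrogen on a nitrogen on an aromatic ring puts methyl in place of hydrogen on a nitrogen on an aromatic ring, turning methylamino to dimethylamino and giving compound 4 `CCCCCCCCCC(CCO)n1cnc2c(N(C)C)ncnc21` from compound 3. For the measured compounds named here, no measured step makes this exact change. The closest, a 2.1-fold higher number from compound 2 to compound 3 (0.33 log units; beyond the scatter) for methylamino in place of methoxy, is modest. Compound 1 at 19800 nM already carries dimethylamino, though on a shorter chain. In this assay a modest step toward a higher number is therefore expected, with a 1.7-fold higher number from compound 3 to compound 4 (0.22 log units; within the scatter) as the estimate. The estimate for compound 4 is 9000 nM with 4000 nM to 20000 nM as the expected range.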

Compound 4, half-maximal inhibitory concentration: 9810 nM
The estimate for compound 4 lay 1.1-fold (0.04 log units) below the measured number; the range from low to high includes it.
By their numbers in this assay, from the lowest: compound 2; then compounds 3, 4 and 1 (each within the scatter of the next, the first and the last beyond it).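

In this assay a second methyl on this nitrogen gives a 1.8-fold higher number from compound 3 to compound 4 (0.26 log units; within the scatter) and so does not separate dimethylamino from methylamino. Against methoxy, dimethylamino does stand apart, with a 3.9-fold higher number from compound 2 to compound 4 (0.59 log units; beyond the scatter). Methyl in place of hydrogen on a saturated chain carbon, nine bonds along the chain from an aromatic nitrogen, gives a 2.0-fold lower number from compound 1 to compound 4 (0.30 log units; within the scatter), so that chain change is not resolved either.

No measurement shown here explains these steps. From the compounds shown here alone, how an ethylamino group or a morpholine ring would read on this aromatic carbon remains open.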